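A few compounds are considered here, and "the series" means these few. Any claim that something is new, unique, unknown or untested is made for them only; others in the source may bear on it.

Working notes on the series. In an ADME assay on NHDF cells (Homo sapiens) for cytotoxicity, read by MTT assay, with a stated time of 72 h (on this read-out lower numbers stand for stronger inhibition and higher numbers for weaker inhibition), compound 2 (`COc1ccc(/C=C2\CCC/C(=C\c3ccc(Cl)cc3)C2=O)cc1OC`) gives 11200 nM and compound 1 (`COc1ccc(/C=C2\CCC/C(=C\c3ccccc3Cl)C2=O)cc1OC`) gives 21600 nM. Within the data shown here, these are the only two numbers so far, and they lie within the scatter of each other, so compound 2 has no separate standing.

The next structure is compound 3 (`COc1ccc(/C=C2\CCC/C(=C\c3ccccc3Br)C2=O)cc1OC`), with this change: 2-bromophenyl in place of 4-chlorophenyl on a double-bonded chain carbon bound to a double-bonded ring carbon. In words, 2-bromophenyl stands in place of 4-chlorophenyl on a double-bonded chain carbon bound to a double-bonded ring carbon.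

Among the measured compounds shown here, one measured step bears on this place: a 1.9-fold lower number from compound 1 to compound 2 (0.29 log units; within the scatter). It exchanges 2-chlorophenyl for 4-chlorophenyl and stays within the scatter. For the measured compounds named here, no measured compound carries 2-bromophenyl, so that group has no direct data behind it. Its name shares the 2 of the group in compound 1, which gives 21600 nM, and the estimate leans slightly toward that value. No step beyond the scatter is expected in this assay.

The estimated change is a 1.4-fold higher number from compound 2 to compound 3 (0.15 log units; within the scatter).

For compound 3 the expected value is 16000 nM, with an estimated range of 7500 nM to 34000 nM.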

Compound 3, half-maximal inhibitory concentration: 21800 nM
Estimate against measurement, compound 3: 1.4-fold (0.13 log units) below, within the range that was stated.
By their numbers in this assay, from the lowest: compounds 2, 1 and 3 (each within the scatter of the next).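

In this assay, bromo in place of chloro on an aromatic carbon gives a 1.0-fold higher number from compound 1 to compound 3 (0.00 log units; within the scatter) and so adds a second halogen at this place without any step beyond the scatter. The wider exchange of 4-chlorophenyl for 2-bromophenyl gives a 1.9-fold higher number from compound 2 to compound 3 (0.29 log units; within the scatter) and also stays within the scatter, so 2-chlorophenyl, 4-chlorophenyl and 2-bromophenyl on a double-bonded chain carbon bound to a double-bonded ring carbon cannot be told apart on these numbers. No measurement at hand bears on what lies behind this closeness.

From the compounds shown here alone, all three groups are halogen-bearing phenyl groups, so it remains open whether a phenyl group carrying an amine or a carboxylic acid, or a longer chain in place of the phenyl ring, would produce a step beyond the scatter at this place. The rest of the shared core is the same in all three compounds, so these numbers also say nothing about how changes elsewhere would read in this assay.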